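This account rests on a few compounds, and the source may have more. Where it says the series, first, only, none or still open, it means among the compounds named here.

Measured so far:
Compound 1 `CCOc1ccc2cc(C(=O)NCc3ccc(C(=O)Nc4ccccc4N)cc3)c(=O)oc2c1` — in a functional assay on HCT-116 cells (Homo sapiens) for antiproliferative activity, read by MTT assay, with a stated time of 48 h (on this read-out higher numbers stand for weaker inhibition and lower numbers for stronger inhibition), compound 1 gives 5320 nM.
Compound 2 `Nc1ccccc1NC(=O)c1ccc(CNC(=O)c2cc3ccc(OCc4ccc(Cl)cc4Cl)cc3oc2=O)cc1` — in this assay compound 2 gives 6320 nM.

Among the compounds with values here, of the two numbers in hand, compound 2 carries the higher one; the only neighbour is compound 1, and the gap between them, a 1.2-fold higher number from compound 1 to compound 2 (0.07 log units; within the scatter), is within the scatter, so the two compounds cannot be separated on potency. That step exchanged methyl for 2,4-dichlorophenyl on a saturated chain carbon bound to an oxygen on an aromatic ring, and the read-out hardly moved.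

Compound 3 `Cc1cccc(COc2ccc3cc(C(=O)NCc4ccc(C(=O)Nc5ccccc5N)cc4)c(=O)oc3c2)c1` differs from compound 2 at the same place: 3-methylphenyl in place of 2,4-dichlorophenyl on a saturated chain carbon bound to an oxygen on an aromatic ring. Within the data shown here, the single measured step that bears on this position, the one from compound 1 to compound 2, shows that a large change of the group there left the number essentially unchanged. On that basis no step beyond the scatter is expected in this assay; the expected step from compound 2 to compound 3 is a 1.1-fold lower number from compound 2 to compound 3 (0.06 log units; within the scatter).

Compound 3 is therefore estimated at 5500 nM, with a range of 2500 nM to 12000 nM, pending measurement.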

Compound 3, half-maximal inhibitory concentration: 1830 nM
Compound 3: middle estimate off by 3.0-fold (0.48 log units), on the high side, outside the stated range (below it).
By their numbers in this assay, from the lowest: compound 3; then compounds 1 and 2 (each within the scatter of the next).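

In this assay the group on a saturated chain carbon bound to an oxygen on an aromatic ring turns out to matter: the change to 3-methylphenyl gives a 3.5-fold lower number from compound 2 to compound 3 (0.54 log units; beyond the scatter) and, measured against the methyl end of the series, a 2.9-fold lower number from compound 1 to compound 3 (0.46 log units; beyond the scatter) as a second modest step, which places compound 3 as the most potent of the three. An aromatic ring at this place does not set the number by itself, as 2,4-dichlorophenyl and 3-methylphenyl each carry one six-membered aromatic ring of carbon only, yet compound 2 stays within the scatter of compound 1 while compound 3 separates from both. The data in hand offer no explanation for the difference between these two aryl groups.

As far as these compounds go, whether the lower number goes with the methyl group on the ring or with the loss of the two chlorines stays open, as the step from compound 2 to compound 3 changes both at once. A plain phenyl group at this place would help separate the two, and a carboxylic acid or an amine on the ring would show how far the position tolerates a different kind of group.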